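Shortening the Acyl Chain on a Trimethoxyphenyl Amide

A few compounds are considered here, and "the series" means these few. Any claim that something is new, unique, unknown or untested is made for them only; others in the source may bear on it.

The series rests on an amide-linked pair of aryl groups, and its two measured members sit far apart. In a functional assay on HCT-116 cells (Homo sapiens) for inhibition, read by MTT assay, with a stated time of 48 h (on this read-out higher numbers stand for weaker inhibition and lower numbers for stronger inhibition), compound 1 `COC(=O)c1cc(CNc2cc(OC)c(OC)c(OC)c2)ccc1OC` gives 38100 nM. Compound 2 `C/C=C/C=C/C(=O)N(Cc1ccc(OC)c(O)c1)c1cc(OC)c(OC)c(OC)c1` carries a penta-1,3-dien-1-yl group on the carbonyl carbon, and in this assay compound 2 gives 180 nM, the lowest number of the two, with compound 1 standing far above it by a gap well beyond the usual scatter.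

Compound 3 `C=CC(=O)N(Cc1ccc(OC)c(O)c1)c1cc(OC)c(OC)c(OC)c1` has not yet been measured. It differs from compound 2 in one place: vinyl in place of penta-1,3-dien-1-yl on a carbonyl carbon. The acyl chain is cut short while the rest of the molecule is kept.

Among the compounds with values here, no measured pair in this set shows what such a truncation does, so the expectation leans on compound 2 alone. Compound 3 is expected to give 400 nM in this assay, with a plausible range from 120 nM to 1500 nM. The step of a 2.2-fold higher number from compound 2 to compound 3 (0.35 log units; beyond the scatter) is thus expected to be a modest loss, possibly within the scatter of the assay.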

Compound 3, half-maximal inhibitory concentration: 98 nM
Compound 3: middle estimate off by 4.1-fold (0.61 log units), on the high side; the whole stated range lies above it.
By their numbers in this assay, from the lowest: compounds 3 and 2 (each within the scatter of the next); then compound 1.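

Replacing penta-1,3-dien-1-yl with vinyl on a carbonyl carbon whose other neighbour is an amide-type nitrogen gives a 1.8-fold lower number from compound 2 to compound 3 (0.26 log units; within the scatter) in this assay, so the two compounds cannot be told apart in this read-out. This shows what compound 2 alone could not: the number it reached does not depend on the full chain of 5 heavy atoms and 2 double bonds, since vinyl, with 2 heavy atoms and 1 double bond, gives a value within the scatter of it. Nothing shown here accounts for why these two acyl groups read alike.

The compounds shown leave open whether an unsaturated group is needed at this position at all, which an ethyl group in place of vinyl would address, and how far the position accepts other groups, such as a longer chain, a phenyl ring or a chain ending in a dimethylamino group. They also leave open which feature separates compound 1 from the other two, as it differs from them in more than one place.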